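Extending the Chain of Compound 2

The source may report more compounds than this note shows. Statements on the series, on what has been measured and on what is new or still open speak of the compounds shown alone.

Compound 1 `Clc1nccnc1C1CN2CCC1CC2`: 1590000 nM
Compound 2 `CCCCCOc1nccnc1C1CN2CCC1CC2`: 9130000 nM
Compound 3 `CCCCCCOc1nccnc1[C@@H]1CN2CCC1CC2`: 360000 nM

In a functional assay on A9L-m1 cells with A9 (Mus musculus) as the target (a lower number here means that less compound is needed, a higher number that more compound is needed for the effect), compound 2 gives 9130000 nM, the highest of the three numbers. Compound 4 `CCCCCCCOc1nccnc1C1CN2CCC1CC2` has not yet been measured. It departs from compound 2 by one change, (ethyl in place of hydrogen on a saturated chain carbon, five bonds along the chain from an oxygen on an aromatic ring), which puts ethyl in place of hydrogen on a saturated chain carbon, five bonds along the chain from an oxygen on an aromatic ring.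

For the measured compounds named here, the only measured step is a 5.7-fold higher number from compound 1 to compound 2 (0.76 log units; beyond the scatter), a modest one beyond the scatter. It swaps chloro for pentyloxy, so it is a different change and bears on this one only loosely. Going by the values given here, no measured step extends the chain itself. The closest guide is compound 3, whose 360000 nM lies well under the number of compound 2. With compound 2 at the top of the set, a modest move to a lower number is expected in this assay, as a 6.1-fold lower number from compound 2 to compound 4 (0.78 log units; beyond the scatter) in the estimate.

Compound 4 is estimated at 1500000 nM, with an expected range from 200000 nM to 9000000 nM.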

Compound 4, half-maximal effective concentration: 400000 nM
For compound 4 the middle estimate is 3.8-fold (0.57 log units) above the measured one; the range from low to high includes it.
By their numbers in this assay, from the lowest: compounds 3 and 4 (each within the scatter of the next); then compound 1; then compound 2.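

In this assay, ethyl in place of hydrogen on a saturated chain carbon, five bonds along the chain from an oxygen on an aromatic ring, gives a 23-fold lower number from compound 2 to compound 4 (1.36 log units; beyond the scatter), a large step beyond the scatter. The earlier step, a 5.7-fold higher number from compound 1 to compound 2 (0.76 log units; beyond the scatter), concerned only the replacement of chloro by pentyloxy on an aromatic carbon, whereas this result shows that the number also responds strongly to a change far out along the chain, and in the opposite direction. No supporting information accounts for the size of this step.

The compounds shown leave open whether a longer chain at this carbon would lower the number further or reverse the step. They also leave open how an amine or a carboxylic acid at this carbon would compare with ethyl.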